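The compounds below may be only part of what the source reports. "The series", "measured", "known", "first", "only" and "open" are said of these compounds alone.

In a functional assay on MCF7 cells (Homo sapiens) for antiproliferative activity, read by MTT assay, with a stated time of 24 h (on this read-out lower numbers stand for stronger inhibition and higher numbers for weaker inhibition), three amides on a shared core have been measured: compound 1 (`CCCCc1oc2ccccc2c1C(=O)c1ccc(OCC(=O)N2CCCC2)cc1`) gives 42400 nM, compound 2 (`CCCCc1oc2ccccc2c1C(=O)c1ccc(OCC(=O)N2CCOCC2)cc1`) gives 34000 nM and compound 3 (`CCCCc1oc2ccccc2c1C(=O)c1ccc(OCC(=O)Nc2ccccc2)cc1`) gives 33600 nM. Compound 3 therefore stands level with the other two, within the scatter. Compound 4 (`CCCCc1oc2ccccc2c1C(=O)c1ccc(OCC(=O)NCc2ccccc2)cc1`) carries benzyl in place of phenyl on an amide-type nitrogen. The bearing evidence is the exchange of the group on the carbonyl carbon: a 1.2-fold lower number from compound 1 to compound 2 (0.10 log units; within the scatter), a 1.3-fold lower number from compound 1 to compound 3 (0.10 log units; within the scatter) and a 1.0-fold lower number from compound 2 to compound 3 (0.01 log units; within the scatter), each within the scatter. No change beyond the scatter is therefore expected in this assay. The expected step is a 1.0-fold lower number from compound 3 to compound 4 (0.01 log units; within the scatter). Compound 4 is estimated at 33000 nM, with an expected range of 15000 nM to 70000 nM.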

Compound 4, half-maximal inhibitory concentration: 19600 nM
Estimate against measurement, compound 4: 1.7-fold (0.23 log units) above; measured number inside the range.
By their numbers in this assay, from the lowest: compounds 4, 3, 2 and 1 (each within the scatter of the next, the first and the last beyond it).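

In this assay, benzyl in place of phenyl on an amide-type nitrogen gives a step within the scatter (a 1.7-fold lower number from compound 3 to compound 4 (0.23 log units; within the scatter)), and exchanging the morpholin-4-yl group for the benzylamino group does too (a 1.7-fold lower number from compound 2 to compound 4 (0.24 log units; within the scatter)). Benzylamino in place of pyrrolidin-1-yl, however, gives the first exchange in this series beyond the scatter, though only a modest one (a 2.2-fold lower number from compound 1 to compound 4 (0.34 log units; beyond the scatter)). Nothing measured here accounts for that step.

Open, going by these compounds, is whether phenethyl on the amide-type nitrogen would lower the number further. Also open, on these data alone, is what an amine or a carboxylic acid on the benzyl group would do.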